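This account rests on a few compounds, and the source may have more. Where it says the series, first, only, none or still open, it means among the compounds named here.

Measured so far in a functional assay on HeLa cells (Homo sapiens) for inhibition, read by MTT assay, with a stated time of 48 h; on this read-out higher numbers stand for weaker inhibition and lower numbers for stronger inhibition:
- compound 1 `Oc1ccc(C(c2c[nH]c3ccc(Br)cc23)c2c[nH]c3ccc(Br)cc23)cc1`: 4000 nM
- compound 2 `COc1ccc(C(c2c[nH]c3ccc(Br)cc23)c2c[nH]c3ccc(Br)cc23)c(OC)c1`: 63200 nM

Within the data shown here, compound 2 holds the higher of the two numbers, so it is the weaker of the pair, and compound 1 is its only neighbour. Among the measured compounds shown here, the one measured step, a 16-fold higher number from compound 1 to compound 2 (1.20 log units; beyond the scatter), is large and beyond the scatter. Only the group on a saturated chain carbon bound to two aromatic carbons differs in that step.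

Compound 3 `Brc1ccc2[nH]cc(C(c3c[nH]c4ccc(Br)cc34)C3CCCCC3)c2c1` changes the same place again: cyclohexyl in place of 2,4-dimethoxyphenyl on a saturated chain carbon bound to two aromatic carbons. For the measured compounds named here, no compound with cyclohexyl has been measured, so the direction rests on thin evidence. The step of a 16-fold higher number from compound 1 to compound 2 (1.20 log units; beyond the scatter) shows that the number in this assay can move a long way with the group at this carbon. Compound 2 also sits at the top of the measured range, so a move toward compound 1 at 4000 nM seems more likely than a further rise. The expected change, toward a lower number and beyond the scatter, is a 4.0-fold lower number from compound 2 to compound 3 (0.60 log units; beyond the scatter). For compound 3 the estimated value is 16000 nM, with an expected range of 4000 nM to 60000 nM.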

Compound 3, half-maximal inhibitory concentration: 3200 nM
Beside the measured number, compound 3's estimate is 5.0-fold (0.70 log units) above it; measured number below the stated range.
By their numbers in this assay, from the lowest: compounds 3 and 1 (each within the scatter of the next); then compound 2.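

In this assay the change to cyclohexyl gives a 20-fold lower number from compound 2 to compound 3 (1.30 log units; beyond the scatter) and so shows that the high number of compound 2 is not shared by every replacement of 4-hydroxyphenyl at this carbon. The comparison a 1.3-fold lower number from compound 1 to compound 3 (0.10 log units; within the scatter) puts cyclohexyl level with 4-hydroxyphenyl, so neither an aromatic ring nor a hydrogen-bond donor or acceptor in this group is needed for a number in this range, and 2,4-dimethoxyphenyl alone stands apart among the three compounds. Nothing on hand gives a reason for the separation of compound 2 from the other two.

The compounds shown leave open whether the high number of compound 2 goes with the methoxy groups as a pair or with either one alone, which a plain phenyl group and a phenyl group carrying a single methoxy group would help to separate. Also open, from the compounds shown here alone, is how far the group at this carbon can vary beyond six-membered rings of carbon, for example with a longer chain such as hexyl, a piperidine ring, or a phenyl group carrying a carboxylic acid.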